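The source may hold more compounds than are shown below. What is called first, only, known or untested is meant among the compounds shown, and "the series" means these compounds.

Series notes. Compound 1 `Cc1ccc(OCC(=O)N(Cc2cccs2)C2COC2)cc1` is measured in an assay on HEK293 cells for agonist activity at transient receptor potential cation channel subfamily M member 8 (Homo sapiens), read by fluorescence and calcium flux, with a stated time of 15 min (a higher number here means that more compound is needed for the effect, a lower number that less compound is needed), at 23000 nM. Compound 2 `CCN(Cc1cccs1)C(=O)COc1ccc(C(=O)O)cc1` is reported in this assay as "not active" (no number reported), with no number given. Compound 3 `CCN(Cc1cc[nH]c1)C(=O)COc1ccc(C)cc1` gives 21800 nM in this assay; its number and that of compound 1 sit within the scatter of each other, so neither is set apart on these figures. The next compound, compound 4 `CCN(Cc1cc[nH]n1)C(=O)COc1ccc(C)cc1`, differs from compound 3 at one point only: 1H-pyrazol-3-yl in place of 1H-pyrrol-3-yl on a saturated chain carbon bound to an amide-type nitrogen. Among the measured compounds shown here, no measured pair shows this change, so the size of the step in this assay cannot be read from the data; the expectation is a step of no more than the scatter, in either direction. Compound 4 is therefore expected to give 22000 nM, in the range 8000 nM to 60000 nM. The step this estimate means is a 1.0-fold higher number from compound 3 to compound 4 (0.00 log units; within the scatter).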

Compound 4, half-maximal effective concentration: "not active" (no number reported)
Compound 4 has no reported number here; no gap can be computed for the estimate.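

Among the compounds shown here, compound 4 carries no number in this assay, so no step from compound 3 to compound 4 can be read. No measurement shown explains this result. The compounds shown leave open how far 1H-pyrazol-3-yl and 1H-pyrrol-3-yl differ in this series.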